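Trading a Carboxy Group for a Methoxy Group

The source may report more compounds than this note shows. Statements on the series, on what has been measured and on what is new or still open speak of the compounds shown alone.

Of the compounds shown here, three have been measured so far in a functional assay on Ehrlich cells (Mus musculus) for inhibition; on this read-out higher numbers stand for weaker inhibition and lower numbers for stronger inhibition. Compound 2 `O=C(O)c1ccc2c(O)c(C(=O)O)cnc2c1` gives 5750000 nM, the highest number of the three, which makes it the weakest inhibitor among them. Among the compounds with values here, compound 3 `CN(C)c1ccc2c(O)c(C(=O)O)cnc2c1` gives 468000 nM, and compound 1 `O=C(O)c1cnc2cc(OCc3cccc4ccccc34)ccc2c1O` gives 85100 nM, the lowest number so far.

Compound 4 `COc1ccc2c(O)c(C(=O)O)cnc2c1` has not yet been measured. It differs from compound 2 in one place: methoxy in place of carboxy on an aromatic carbon. In short, it has methoxy in place of carboxy on an aromatic carbon.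

Within the data shown here, only one measured step involves a similar swap, with dimethylamino in place of carboxy on an aromatic carbon. That change gave a 12-fold lower number from compound 2 to compound 3 (1.09 log units; beyond the scatter), a large move towards stronger inhibition. It is a single example with a different incoming group, so it offers a direction and a rough size rather than a firm rule. On the strength of that step, a lower number of broadly similar size is expected in this assay, well beyond the scatter. The expected change is a 7.2-fold lower number from compound 2 to compound 4 (0.86 log units; beyond the scatter). Compound 4 is estimated at 800000 nM, with an expected range from 300000 nM to 2500000 nM.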

Compound 4, half-maximal inhibitory concentration: 525000 nM
Compound 4: the middle estimate sits 1.5-fold (0.18 log units) above what was measured, and the stated range covers the measured number.
By their numbers in this assay, from the lowest: compound 1; then compounds 3 and 4 (each within the scatter of the next); then compound 2.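

This position on the aromatic carbon now has two different replacements for carboxy to compare. In this assay, methoxy in place of carboxy gives an 11-fold lower number from compound 2 to compound 4 (1.04 log units; beyond the scatter), a large move in the same direction as the dimethylamino swap, which gave a 12-fold lower number from compound 2 to compound 3 (1.09 log units; beyond the scatter), so the lower number no longer rests on a single incoming group. Methoxy in place of dimethylamino gives a 1.1-fold higher number from compound 3 to compound 4 (0.05 log units; within the scatter), so among these three compounds the clear divide lies between carboxy on one side and the two other groups on the other, while the choice between those two makes no readable difference.

Nothing measured here explains why these steps turn out as they do. Going by these compounds, it also remains open whether a plain hydrogen, an amide or a longer chain such as ethoxy at this position would follow the same trend, and such groups could help separate the effect of losing carboxy from the effect of what replaces it.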